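The source may report more compounds than this note shows. Statements on the series, on what has been measured and on what is new or still open speak of the compounds shown alone.

Measured so far in a functional assay on MOLT-4 cells (Homo sapiens) for cytotoxicity, with a stated time of 72 h; on this read-out lower numbers stand for stronger inhibition and higher numbers for weaker inhibition:
compound 1, `O=C1/C(=C/c2ccccc2)CCC/C1=C\c1cccc([N+](=O)[O-])c1`: 1700 nM
compound 2, `O=C1/C(=C/c2ccc(F)cc2)CCC/C1=C\c1cccc([N+](=O)[O-])c1`: 5120 nM
compound 3, `CN(C)c1ccc(/C=C2\CCC/C(=C\c3ccc([N+](=O)[O-])cc3)C2=O)cc1`: > 500000 nM

Compound 1 and compound 2 both carry a 3-nitrophenyl arm on the shared core and both give a number in this assay. For the measured compounds named here, the only measured single-point step, a 3.0-fold higher number from compound 1 to compound 2 (0.48 log units; beyond the scatter), is a fluoro in place of hydrogen on an aromatic carbon. For compound 3 this assay reports only a limit, > 500000 nM. Per the limit of > 500000 nM in this assay, at which 1 of the 3 values shown sits, compound 3 is the only one of the three sitting at that limit, with no number inside the range.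

Compound 4, `CN(C)c1ccc(/C=C2\CCC/C(=C\c3cccc([N+](=O)[O-])c3)C2=O)cc1`, keeps the dimethylaminophenyl arm of compound 3 and differs from it by 3-nitrophenyl in place of 4-nitrophenyl on a double-bonded chain carbon bound to a double-bonded ring carbon. Going by the values given here, no measured step covers this exchange: compound 1 and compound 2 carry the 3-nitrophenyl arm, but each differs from compound 3 in more than one place, so their values only show that a 3-nitrophenyl arm can coexist with measurable potency. The fluoro step from compound 1 to compound 2 does not bear on a nitro shift.

Compound 4 is therefore expected to stay near where compound 3 sits, most likely again at the limit, with the expected step of an at least 1.6-fold lower number from compound 3 to compound 4 (0.22 log units; that floor lies within the scatter) not beyond the scatter. The estimate for compound 4 is 300000 nM, range 20000 nM to 500000 nM.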

Compound 4, half-maximal inhibitory concentration: 10900 nM
Compound 4: the middle estimate sits 28-fold (1.44 log units) above what was measured; measured number outside the range, below it.
By their numbers in this assay, from the lowest: compound 1; then compound 2; then compound 4. At a limit, above all of these: compound 3.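

In this assay, the change of 3-nitrophenyl in place of 4-nitrophenyl on a double-bonded chain carbon bound to a double-bonded ring carbon, with the dimethylaminophenyl arm held fixed, gives an at least 45-fold lower number from compound 3 to compound 4 (1.66 log units; beyond the scatter), so this single exchange separates a compound with a number from one without. Compound 3 has a limit and not a number: the limit of > 500000 nM in this assay, at which 1 of the 4 values shown sits. With the 3-nitrophenyl arm fixed, the dimethylamino group still leaves a measurable value, with a 2.1-fold higher number from compound 2 to compound 4 (0.33 log units; beyond the scatter) for dimethylamino in place of fluoro and a 6.4-fold higher number from compound 1 to compound 4 (0.81 log units; beyond the scatter) for dimethylamino in place of hydrogen, both modest beside the nitro shift.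

On these data alone, it stays open whether 4-nitrophenyl gives as weak a result alongside the unsubstituted phenyl arm of compound 1 or the fluorophenyl arm of compound 2 as it does alongside the dimethylaminophenyl arm. Also open, as far as these compounds go, is how a 2-nitrophenyl arm, or a nitrile or a methoxy group in place of the nitro group, would read in this assay.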